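A phenyl added to the propyl chain of compound 2

A few compounds are considered here, and "the series" means these few. Any claim that something is new, unique, unknown or untested is made for them only; others in the source may bear on it.

Measured in a functional assay on HGC-27 cells (Homo sapiens) for inhibition, read by MTT assay, with a stated time of 72 h; a higher number here means a weaker inhibitor, a lower number a stronger inhibitor:
- Compound 1 `Cc1cc(N2CC[C@@H](C)[C@@H](N(C)c3ncnc4[nH]ccc34)C2)n2nc(SCc3ccc(F)c(Cl)c3)nc2n1`: > 100000 nM (a limit, not a number)
- Compound 2 `CCCSc1nc2nc(C)cc(N3CC[C@@H](C)[C@@H](N(C)c4ncnc5[nH]ccc45)C3)n2n1`: 20900 nM

Among the measured compounds shown here, compound 2 holds the only exact number so far. Compound 3 `Cc1cc(N2CC[C@@H](C)[C@@H](N(C)c3ncnc4[nH]ccc34)C2)n2nc(SCCCc3ccccc3)nc2n1` differs from it by phenyl in place of hydrogen on a saturated chain carbon, three bonds along the chain from a sulfur: phenyl in place of hydrogen. For the measured compounds named here, one measured step bears on this change: an at least 4.7-fold lower number from compound 1 to compound 2 (0.67 log units; beyond the scatter), where an aromatic ring on the sulfur chain gave way to ethyl. Compound 3 brings an aromatic ring back to that chain, though a different one from that of compound 1. A modest move to a higher number is therefore expected: a 2.2-fold higher number from compound 2 to compound 3 (0.33 log units; beyond the scatter). For compound 3, the estimated value is 45000 nM, with an expected range of 15000 nM to 100000 nM.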

Compound 3, half-maximal inhibitory concentration: > 100000 nM
Compound 3 gave a limit, no number; the forecaster's own chance of this, stated with the estimate: 30%; middle value at least 2.2-fold (0.34 log units) away from the limit.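

Adding phenyl to the propyl chain gives an at least 4.7-fold higher number from compound 2 to compound 3 (0.67 log units; beyond the scatter) in this assay. A plain phenyl on the sulfur chain thus goes with a higher number, as the 3-chloro-4-fluorophenyl of compound 1 did, so the halogens on that ring are not needed for this shift. Compound 3 gives a limit, not a number, as does compound 1, so the step between them cannot be read: the limit of > 100000 nM in this assay, at which 2 of the 3 values shown sit.

As far as these compounds go, how far past that limit either compound lies stays open. So does whether an amine or a carboxylic acid in place of the phenyl would lower the number of compound 2.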